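Replacing isopropyl with methylsulfanyl on the Z compound

The compounds below may be only part of what the source reports. "The series", "measured", "known", "first", "only" and "open" are said of these compounds alone.

Measured so far in a functional assay on HT-29 cells (Homo sapiens) for cytotoxicity (a higher number here means that more compound is needed for the effect, a lower number that less compound is needed), are two compounds:
- Compound 1 `COc1cc(/C=C/c2ccc(C(C)C)cc2)cc(OC)c1OC` gives 6.8 uM
- Compound 2 `COc1cc(/C=C\c2ccc(C(C)C)cc2)cc(OC)c1OC` gives 2.4 uM

Compound 2 holds the lower of the two numbers, and its gap to compound 1 lies beyond the scatter. Compound 3 `COc1cc(/C=C\c2ccc(SC)cc2)cc(OC)c1OC` has yet to be measured in this assay and keeps the Z double bond of compound 2. The change is methylsulfanyl in place of isopropyl on an aromatic carbon and puts methylsulfanyl in place of isopropyl on an aromatic carbon. Within the data shown here, only one measured step exists, namely a 2.8-fold lower number from compound 1 to compound 2 (0.45 log units; beyond the scatter) and it is modest. It comes with the fact that compounds 1 and 2 differ only in the configuration as drawn so it concerns the double bond and leaves the isopropyl group untouched. Among the measured compounds shown here, no measured step shows what replacing that group does, so neither size nor direction can be read from the data. A small move toward a lower number is expected, but only tentatively. The expected change is a 2.0-fold lower number from compound 2 to compound 3 (0.30 log units; within the scatter) and the range is kept wide for that reason. For compound 3 the estimated value is 1.2 uM with an expected range from 0.15 uM to 5 uM once it is measured.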

Compound 3, concentration for half-maximal effect: 1.8 uM
The estimate for compound 3 lay 1.5-fold (0.18 log units) below the measured number; the range from low to high includes it.
By their numbers in this assay, from the lowest: compounds 3 and 2 (each within the scatter of the next); then compound 1.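

Among these compounds, this is the first result that touches the group on the aromatic carbon itself, since the only earlier step concerned the double bond and left the isopropyl group in place. In this assay, the swap of isopropyl for methylsulfanyl on the Z compound gives a 1.3-fold lower number from compound 2 to compound 3 (0.12 log units; within the scatter), so the assay does not separate the two groups at this position, although methylsulfanyl brings a sulfur atom and a hydrogen-bond acceptor that isopropyl does not have and one heavy atom fewer. The position therefore accepts this particular exchange with no change that can be read in this assay, and nothing at hand explains why these two groups read alike.

The compounds shown leave open whether this position is tolerant in general or whether these two groups merely happen to match, as an amine, a carboxylic acid or a longer chain on the same aromatic carbon would show. They also leave open whether methylsulfanyl matches isopropyl on the E double bond as well, since every comparison of the two groups so far rests on the Z form alone.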